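Adding a second chloro to the aryl ring of compound 3

The source may report more compounds than this note shows. Statements on the series, on what has been measured and on what is new or still open speak of the compounds shown alone.

Compound 1 `N#C/C(=C\N1CCN(C(=O)c2ccco2)C1=S)C(N)=O`: 3800 nM
Compound 2 `N#C/C(=C\N1CCN(C(=O)c2ccco2)C1=S)C(=O)c1ccccc1`: 5700 nM
Compound 3 `O=CN1CCN(c2ccc(Cl)cc2)C1=S`: 21300 nM

In a functional assay on HCT-15 cells (Homo sapiens) for inhibition, read by sulforhodamine B assay, with a stated time of 48 h (on this read-out lower numbers stand for stronger inhibition of growth and higher numbers for weaker inhibition of growth), compound 3 gives the highest number of the three, compound 2 sitting at a number lower by a margin beyond the scatter, and compound 1 lower still. Among the compounds with values here, the only step between measured compounds that differ in one place, a 1.5-fold higher number from compound 1 to compound 2 (0.18 log units; within the scatter), concerns the amide carbon of a different series and says nothing about substitution on the aryl ring of compound 3.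

Compound 4 `O=CN1CCN(c2ccc(Cl)c(Cl)c2)C1=S` differs from compound 3 by chloro in place of hydrogen on an aromatic carbon. Within the data shown here, no measured pair speaks to this change; compound 3 is the only member of its series with a number, so nothing points to a move in either direction. The writer therefore expects a step from compound 3 to compound 4 of no more than the usual scatter, a 1.3-fold lower number from compound 3 to compound 4 (0.12 log units; within the scatter), and treats any drift as unknown.

For compound 4 in this assay the estimate is 16000 nM, with a range from 5000 nM to 50000 nM.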

Compound 4, concentration for 50% growth inhibition: 19300 nM
Beside the measured number, compound 4's estimate is 1.2-fold (0.08 log units) below it; the range from low to high includes it.
By their numbers in this assay, from the lowest: compounds 1 and 2 (each within the scatter of the next); then compounds 4 and 3 (each within the scatter of the next).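

In this assay, the added chloro gives a 1.1-fold lower number from compound 3 to compound 4 (0.04 log units; within the scatter), a step within the scatter, so this read-out does not separate the two compounds. Within the data shown here, this is the first measured step on the aryl ring of this series, and it shows that the new chloro, ortho to a chloro group and meta to a group of 8 heavy atoms, leaves the growth-inhibition number of compound 3 essentially unchanged. No available evidence bears on why this substitution makes so little difference to the number.

Going by these compounds, the result covers a single group at a single position, so it remains open whether a methoxy group, an amine or a carboxylic acid at this same carbon would also leave the number unchanged. Also open, on these data alone, is what the chloro group already present in compound 3 contributes, and whether a second chloro at another carbon of the aryl ring would give a step as small as this one.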